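This account rests on a few compounds, and the source may have more. Where it says the series, first, only, none or still open, it means among the compounds named here.

Measured so far:
compound 1, `O=C(Nc1cccc(-n2cc(-c3ccncc3)c(-c3ccc(Cl)c(O)c3)n2)c1)Nc1cccc(C(F)(F)F)c1`: > 32500 nM
compound 2, `COc1cc(-c2nn(-c3cccc(NC(=O)Nc4cc(C(F)(F)F)cc(C(F)(F)F)c4)c3)cc2-c2ccncc2)ccc1Cl`: 5720 nM
compound 3, `COc1cc(-c2nn(-c3cccc(NC(=O)Nc4cccc(C(F)(F)F)c4)c3)cc2-c2ccncc2)ccc1Cl`: 3720 nM

In a functional assay on ACHN cells (Homo sapiens) for inhibition, read by sulforhodamine B assay, with a stated time of 48 h (a higher number here means a weaker inhibitor of growth, a lower number a stronger inhibitor of growth), compound 2 gives 5720 nM, the higher of the two numbers recorded there. Among the compounds with values here, the only other number is that of compound 3, which gives 3720 nM in this assay; the step of a 1.5-fold lower number from compound 2 to compound 3 (0.19 log units; within the scatter), so the two cannot be told apart. For compound 1 this assay reports only a limit, > 32500 nM, and no number.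

Compound 4, `O=C(Nc1cccc(-n2cc(-c3ccncc3)c(-c3ccc(Cl)c(O)c3)n2)c1)Nc1cc(C(F)(F)F)cc(C(F)(F)F)c1`, differs from compound 2 in one place: hydrogen in place of methyl on an oxygen on an aromatic ring. Within the data shown here, the one measured step that bears on this change runs the opposite way, from hydroxy to methoxy, and was large: an at least 8.7-fold lower number from compound 1 to compound 3 (0.94 log units; beyond the scatter). Read backwards, removing the methyl from compound 2 should raise its number in this assay by a comparable amount, very likely past (the limit of > 32500 nM in this assay, at which 1 of the 3 values shown sits). Compound 4 is therefore expected to give about 60000 nM in this assay, with a range from 15000 nM to 250000 nM. The estimated step is a 10-fold higher number from compound 2 to compound 4 (1.02 log units; beyond the scatter), and the value for compound 4 is expected to appear only as a limit rather than as a number.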

Compound 4, concentration for total growth inhibition: 5270 nM
Compound 4: middle estimate off by 11-fold (1.06 log units), on the high side, outside the stated range (below it).
By their numbers in this assay, from the lowest: compounds 3, 4 and 2 (each within the scatter of the next). At a limit, above all of these: compound 1.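

In this assay, taking the methyl off the oxygen gives a 1.1-fold lower number from compound 2 to compound 4 (0.04 log units; within the scatter), so on the core bearing the extra trifluoromethyl, hydroxy and methoxy cannot be told apart, and the large step seen for the same change on the core of compound 1 does not carry over: the same change on two cores in this assay, an at least 8.7-fold lower number (0.94 log units; beyond the scatter) from compound 1 to compound 3 and a 1.1-fold higher number (0.04 log units; within the scatter) from compound 4 to compound 2, at least 9.4-fold (0.97 log units) apart, beyond the scatter of two such steps Read from the other side, trifluoromethyl in place of hydrogen on an aromatic carbon gives an at least 6.1-fold lower number from compound 1 to compound 4 (0.79 log units; beyond the scatter) when the hydroxy group is present, while the same change is not resolved when the methoxy group is present: the same change on two cores in this assay, a 1.5-fold lower number (0.19 log units; within the scatter) from compound 2 to compound 3 and an at least 6.1-fold higher number (0.79 log units; beyond the scatter) from compound 4 to compound 1, at least 9.4-fold (0.97 log units) apart, beyond the scatter of two such steps The effects of the two changes therefore depend on each other, and this rests entirely on compound 1, whose > 32500 nM is a limit and not a number.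

The compounds shown leave open how far compound 1 truly lies from the other three, so the real size of this dependence remains unknown. They also leave open whether an ethyl group on that oxygen, or an amine in place of the hydroxy, would behave like methoxy or like hydroxy on either core.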